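The source may report more compounds than this note shows. Statements on the series, on what has been measured and on what is new or still open speak of the compounds shown alone.

Compound 1 `COc1ccc(-c2cccc(=O)n2-c2cc(OC)c(OC)c(OC)c2)cc1O`: < 10 nM (a limit of the assay)
Compound 2 `COc1ccc(-c2cccc(=O)n2-c2cc(OC)c(OC)c(OC)c2)cc1OC`: 513 nM
Compound 3 `COc1cc(-c2cccc(=O)n2-c2cc(OC)c(OC)c(OC)c2)cc(OC)c1OC`: not yet measured

Within the data shown here, in a functional assay on HepG2 cells (Homo sapiens) for cytotoxicity, read by spectrophotometry, with a stated time of 72 h (a lower number here means a stronger inhibitor, a higher number a weaker inhibitor), compound 2 gives 513 nM, the only exact number so far. The result for compound 1 is a limit: the limit of < 10 nM in this assay, at which 1 of the 2 values shown sits.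

Compound 3 carries methoxy in place of hydrogen on an aromatic carbon of compound 2: methoxy in place of hydrogen on an aromatic carbon. Among the measured compounds shown here, one measured step bears on this, on the same ring but of a different kind: an at least 51-fold higher number from compound 1 to compound 2 (1.71 log units; beyond the scatter). On the strength of that large step, a smaller move towards a weaker inhibitor is expected, estimated as a 2.9-fold higher number from compound 2 to compound 3 (0.47 log units; beyond the scatter). The estimate for compound 3 is 1500 nM, with an expected range from 300 nM to 8000 nM.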

Compound 3, half-maximal inhibitory concentration: 5460 nM
Estimate against measurement, compound 3: 3.6-fold (0.56 log units) below, and the stated range covers the measured number.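

In this assay, methoxy in place of hydrogen on this aromatic carbon gives an 11-fold higher number from compound 2 to compound 3 (1.03 log units; beyond the scatter), so a ring carbon bearing only hydrogen in compound 2 also has a large bearing on the number, and not just the oxygen substituent changed in the earlier step. On this ring, both measured changes now point towards a weaker inhibitor. Nothing at hand gives a cause for this step. From the compounds shown here alone, how an amine or a carboxylic acid would behave on this aromatic carbon remains open. So does whether the same methoxy step holds when the hydroxyl of compound 1 is present.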